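The source may report more compounds than this note shows. Statements on the series, on what has been measured and on what is new or still open speak of the compounds shown alone.

Among the measured compounds shown here, the three compounds measured so far share one core and differ only in the group carried on an amine nitrogen in a ring. In a functional assay on BGC-823 cells (Homo sapiens) for antiproliferative activity, read by MTT assay, with a stated time of 48 h (a lower number here means a stronger inhibitor, a higher number a weaker inhibitor), compound 1 `COc1ccc(N2CCN(Cn3nc(-c4ccc5c(c4)OCCO5)oc3=S)CC2)cc1` gives 18900 nM, compound 2 `Cc1ccc(N2CCN(Cn3nc(-c4ccc5c(c4)OCCO5)oc3=S)CC2)c(C)c1` gives 28300 nM, and compound 3 `S=c1oc(-c2ccc3c(c2)OCCO3)nn1CN1CCN(c2cccc(Cl)c2Cl)CC1` gives 22600 nM. Among these three numbers compound 3 stands second highest; its nearest neighbour is compound 1, with a 1.2-fold higher number from compound 1 to compound 3 (0.08 log units; within the scatter), and its furthest is compound 2, with a 1.3-fold lower number from compound 2 to compound 3 (0.10 log units; within the scatter). The remaining pair shows a 1.5-fold higher number from compound 1 to compound 2 (0.18 log units; within the scatter). Every one of these steps stays inside the scatter, so the aryl group on this ring nitrogen has not moved the read-out in this assay beyond what repeated measurement alone produces.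

Compound 4 `S=c1oc(-c2ccc3c(c2)OCCO3)nn1CN1CCN(c2ccccc2)CC1` carries the change (phenyl in place of 2,3-dichlorophenyl on an amine nitrogen in a ring). The steps between compounds 1, 2 and 3 all bear on this change, since each of them swaps the aryl group at the same position, and none exceeds the scatter. He therefore expects no step beyond the scatter in this assay, in either direction; the expected step is a 1.0-fold lower number from compound 3 to compound 4 (0.01 log units; within the scatter). His estimate for compound 4 in this assay is 22000 nM, with a range from 10000 nM to 48000 nM.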

Compound 4, half-maximal inhibitory concentration: > 50000 nM
Compound 4 ended at the assay's limit; the forecaster's own chance of this, stated with the estimate: 5%; at least 2.2-fold (0.35 log units) between middle value and limit.
By their numbers in this assay, from the lowest: compounds 1, 3 and 2 (each within the scatter of the next). At a limit, above all of these: compound 4.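

In this assay compound 4, with phenyl on the ring nitrogen, gives > 50000 nM, which is a limit of the assay and not a number: the limit of > 50000 nM in this assay, at which 1 of the 4 values shown sits.

Among the compounds shown here, this position is therefore not as indifferent as the earlier compounds suggested, since an at least 2.2-fold higher number from compound 3 to compound 4 (0.34 log units; beyond the scatter) and an at least 2.6-fold higher number from compound 1 to compound 4 (0.42 log units; beyond the scatter) both exceed the scatter, although an at least 1.7-fold higher number from compound 2 to compound 4 (0.24 log units; that floor lies within the scatter) has a floor that does not separate that pair. Compounds 1, 2 and 3, which carry groups on the phenyl ring, stay within the scatter of one another, and only compounds 1 and 3 are clearly separated from compound 4, with compound 2 the exception.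

Going by these compounds, how far compound 4 lies past the limit remains unknown, so these steps are floors only. The compounds shown also leave open whether a single chlorine, a hydroxyl or an amine on the phenyl ring, or a benzyl group on this nitrogen, would keep the read-out within the range of compounds 1, 2 and 3.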